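A Dichlorophenyl Change Weighed Against Two Earlier Steps

The source may hold more compounds than are shown below. What is called first, only, known or untested is meant among the compounds shown, and "the series" means these compounds.

For the measured compounds named here, compound 1 `CC/C(=C(/c1ccc(/C=C/C(=O)O)cc1)c1cc2ccccc2[nH]1)c1ccccc1OC(F)(F)F` is one of three compounds so far measured in a functional assay on MCF7 cells (Homo sapiens) for inhibition (a lower number here means a stronger inhibitor, a higher number a weaker inhibitor), where compound 1 gives 206 nM. That number is the second highest of the three. Its nearest neighbour is compound 2 `CC/C(=C(/c1ccc(/C=C/C(=O)O)cc1)c1cc2ccccc2[nH]1)c1ccc(Cl)cc1`, which in this assay gives 343 nM; the step of a 1.7-fold higher number from compound 1 to compound 2 (0.22 log units; within the scatter) stays within the scatter. The furthest is compound 3 `CC/C(=C(/c1ccc(/C=C/C(=O)O)cc1)c1cc2ccccc2[nH]1)c1cccc(F)c1C#N`, which in this assay gives 40 nM; the step of a 5.2-fold lower number from compound 1 to compound 3 (0.71 log units; beyond the scatter) lies beyond the scatter, as does the step of an 8.6-fold lower number from compound 2 to compound 3 (0.93 log units; beyond the scatter).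

Compound 4 `CC/C(=C(/c1ccc(/C=C/C(=O)O)cc1)c1cc2ccccc2[nH]1)c1ccc(Cl)cc1Cl` has not yet been measured. It differs from compound 1 in a single place: 2,4-dichlorophenyl in place of 2-(trifluoromethoxy)phenyl on a double-bonded chain carbon bound to a double-bonded chain carbon and a saturated chain carbon. Going by the values given here, of the measured steps, the one from compound 1 to compound 2 bears most directly on this change, since compound 2 likewise carries a chlorine on the phenyl at that place, and that step, a 1.7-fold higher number from compound 1 to compound 2 (0.22 log units; within the scatter), remained within the scatter. The step of a 5.2-fold lower number from compound 1 to compound 3 (0.71 log units; beyond the scatter) involved a cyano and fluoro pairing that compound 4 does not share, so it offers no direct guidance. On this basis compound 4 is expected to show a step of about a 1.2-fold higher number from compound 1 to compound 4 (0.08 log units; within the scatter), not clearly beyond the scatter. The estimate for compound 4 in this assay is therefore 250 nM, with a range from 100 nM to 650 nM.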

Compound 4, half-maximal inhibitory concentration: 11 nM
For compound 4 the middle estimate is 23-fold (1.36 log units) above the measured one, outside the stated range (below it).
By their numbers in this assay, from the lowest: compound 4; then compound 3; then compounds 1 and 2 (each within the scatter of the next).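

In this assay, for the compounds shown here, the place on the double-bonded chain carbon proves far more responsive to chlorine than the earlier compounds showed: replacing 2-(trifluoromethoxy)phenyl with 2,4-dichlorophenyl gives a 19-fold lower number from compound 1 to compound 4 (1.27 log units; beyond the scatter) as a large step, whereas the earlier change to a chlorine-bearing phenyl stayed within the scatter. Going by these compounds alone, the clearest contrast is the single change of chloro in place of hydrogen on an aromatic carbon, which produces a 31-fold lower number from compound 2 to compound 4 (1.49 log units; beyond the scatter) as the largest of the new steps, so the effect of a chlorine on this phenyl depends strongly on the pattern it forms and not merely on its presence. A nitrile is also not required for a low number at this place, since the dichlorinated compound goes further than the cyano and fluoro pairing, with a 3.6-fold lower number from compound 3 to compound 4 (0.56 log units; beyond the scatter) beyond the scatter, and compound 4 stands as the strongest inhibitor of the four.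

Nothing available gives a measured reason for the size of these steps. As far as these compounds go, it remains open whether a bromine or a methyl group in place of either chlorine would preserve this gain, and whether it would carry over to a shared core with a different acid-bearing chain.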